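Working notes: substituting the amine nitrogen in the series

A few compounds are considered here, and "the series" means these few. Any claim that something is new, unique, unknown or untested is made for them only; others in the source may bear on it.

Measured so far:
compound 1 `CC(=O)Nc1ccc(CNc2cc(Br)cc3[nH]ncc23)cc1`: 48%
compound 2 `Nc1cccc(CNc2cc(Br)cc3[nH]ncc23)c1`: 31%
compound 3 `Nc1cc(CNc2cc(Br)cc3[nH]ncc23)ccc1O`: 32%

In an assay for inhibition of Indoleamine 2,3-dioxygenase 1 (Homo sapiens), with a stated time of 1 h, tested at 10 uM (a lower number here means less inhibition, a higher number more inhibition at the concentration tested (going by the name of the read-out)), compound 2 gives 31%, the lowest of the three numbers. Among the measured compounds shown here, the one single-change step in the set, a number 1 percentage points higher from compound 2 to compound 3 (within the scatter), places hydroxy in place of hydrogen on an aromatic carbon and leaves the read-out within the scatter. For the measured compounds named here, compound 1 gives 48%, a gap to compound 2 beyond the scatter, but compound 1 differs from compound 2 in more than one place, so no single step connects them.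

Compound 4 `O=C1CCCC(Nc2cccc(CNc3cc(Br)cc4[nH]ncc34)c2)C1` is not yet measured. It differs from compound 2 by 3-oxocyclohexyl in place of hydrogen on a nitrogen on an aromatic ring. Going by the values given here, no measured step touches a substituent on that nitrogen; the only step available, hydroxy on an aromatic carbon, was within the scatter and bears on this change only loosely. The expected step for compound 4 is therefore a number 9 percentage points higher from compound 2 to compound 4 (within the scatter), a small rise that may not clear the scatter. Compound 4 is estimated at 40%, within a range of 20% to 60%.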

Compound 4, a percentage reported as inhibition, at one concentration (the size of the read-out at that concentration, not a potency): 52%
Compound 4: the middle estimate sits 12 percentage points below what was measured; low and high end bracket the measured number.
By their numbers in this assay, from the lowest: compounds 2 and 3 (each within the scatter of the next); then compounds 1 and 4 (each within the scatter of the next).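

The amino nitrogen of compound 2 accepts a substituent, and in this assay the change to (3-oxocyclohexyl)amino gives a number 21 percentage points higher from compound 2 to compound 4 (beyond the scatter) with the rest of the molecule unchanged. Among the compounds shown here, the only other single change from compound 2, hydroxy in place of hydrogen on an aromatic carbon, gives a number 1 percentage points higher from compound 2 to compound 3 (within the scatter) and so leaves the read-out within the scatter, which makes this nitrogen the first place where one change moves the number beyond it. Nothing available explains the rise.

With only this one group on the nitrogen, the compounds shown cannot separate the contribution of the ring from that of its carbonyl. A plain cyclohexyl group, a 4-oxocyclohexyl isomer or an open chain such as n-butyl on the same nitrogen would address that question.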